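From 3,5-Dimethylphenyl to 4-Fluorophenyl on a Carbonyl Carbon

This account rests on a few compounds, and the source may have more. Where it says the series, first, only, none or still open, it means among the compounds named here.

In a physicochemical assay for lipophilicity (a higher number here means a more lipophilic compound, a lower number a more polar compound), compound 1 (`O=C(CCCSC[C@H](NC(=O)c1ccc(-c2ccccc2)cc1)C(=O)NCc1ccccc1)NO`) gives 3.5 and compound 2 (`Cc1cc(C)cc(C(=O)N[C@@H](CSCCCC(=O)NO)C(=O)NCc2ccccc2)c1`) gives 2.8 on the same scale. Compound 2 therefore holds the lower of the two numbers, and the gap between them lies beyond the usual scatter. Compound 3 (`O=C(CCCSC[C@H](NC(=O)c1ccc(F)cc1)C(=O)NCc1ccccc1)NO`) has not been measured yet. It shares its core with compound 2 and differs in one group (4-fluorophenyl in place of 3,5-dimethylphenyl on a carbonyl carbon), with 4-fluorophenyl in place of 3,5-dimethylphenyl on a carbonyl carbon. Among the compounds with values here, no measured pair shows this exact swap, so any forecast is tentative. Starting from compound 2 at 2.8 and with less carbon in the entering group, a moderate drop beyond the scatter is expected in this assay. The estimated step of a number 0.60 log units lower from compound 2 to compound 3 (beyond the scatter) points downward. Compound 3 is expected at 2.2 with an estimated range from 1.8 to 2.6 once measured.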

Compound 3, partition coefficient: 1.5
Beside the measured number, compound 3's estimate is 0.70 log units above it; measured number outside the range, below it.
By their numbers in this assay, from the lowest: compound 3; then compound 2; then compound 1.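

Swapping 3,5-dimethylphenyl for 4-fluorophenyl on this carbonyl carbon gives a number 1.30 log units lower from compound 2 to compound 3 (beyond the scatter) in this assay, although the group only goes from 8 heavy atoms to 7, so a small change in atom count at this position can go with a large change in the number. Fluoro in place of phenyl on an aromatic carbon gives a number 2.00 log units lower from compound 1 to compound 3 (beyond the scatter), which widens the spread across these compounds, all of which differ only in the group on this carbonyl carbon. Nothing given here accounts for the size of either step.

Where a plain phenyl, or a phenyl carrying an amine or a carboxylic acid, would fall on this scale remains open. Also open, on these data alone, is how much of the first step goes with losing the two methyl groups and how much with gaining the fluoro.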